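Aryl ketone exchange on the shared core, compound 3

This account rests on a few compounds, and the source may have more. Where it says the series, first, only, none or still open, it means among the compounds named here.

Compound 1 `COc1cc(-c2nnc3n2NC(c2ccco2)C(C(=O)c2cccs2)S3)cc(OC)c1OC` and compound 2 `COc1cc(-c2nnc3n2NC(c2ccco2)C(C(=O)c2ccc([N+](=O)[O-])cc2)S3)cc(OC)c1OC` share one core and differ only in the aryl group on the carbonyl carbon. In a functional assay on A549 cells (Homo sapiens) for cytotoxicity, read by MTT assay, with a stated time of 48 h (a lower number here means a stronger inhibitor, a higher number a weaker inhibitor), compound 1 gives 78700 nM. In this assay compound 2 reaches only a limit of the assay, > 100000 nM. Compound 2 therefore stands at the weak end of the numbers shown, with a limit rather than a value. The step of an at least 1.2-fold higher number from compound 1 to compound 2 (0.10 log units; that floor lies within the scatter) is the only measured one at this position, and it is bounded by the limit of > 100000 nM in this assay, at which 1 of the 2 values shown sits, so its true size is not known. Compound 3 `COc1cc(-c2nnc3n2NC(c2ccco2)C(C(=O)c2cccc(Br)c2)S3)cc(OC)c1OC` carries the change (3-bromophenyl in place of 4-nitrophenyl on a carbonyl carbon). Going by the values given here, with one open-ended step as the sole guide, no movement beyond the scatter is expected, and the expected step of a number no higher from compound 2 to compound 3 (the limit leaves the size open) stays near the limit. Compound 3 is estimated at 100000 nM, within 40000 nM to 250000 nM.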

Compound 3, half-maximal inhibitory concentration: 36900 nM
Compound 3: the middle estimate sits 2.7-fold (0.43 log units) above what was measured; measured number outside the range, below it.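

In this assay the aryl group on the carbonyl carbon now shows a movement of readable size: 3-bromophenyl gives a 2.1-fold lower number from compound 1 to compound 3 (0.33 log units; beyond the scatter). Against the 4-nitrophenyl group it gives an at least 2.7-fold lower number from compound 2 to compound 3 (0.43 log units; beyond the scatter), and this step is only a floor, as compound 2 stands at a limit of the assay: the limit of > 100000 nM in this assay, at which 1 of the 3 values shown sits. Compound 3 is thus the strongest of the three shown, although the shifts are modest and a single bromine-bearing ring carries the whole result.

Still open, as far as these compounds go, is whether the bromine or the phenyl ring itself accounts for the gain, which a plain phenyl group would address. Equally open, from the compounds shown here alone, is how this position responds to an aryl ring carrying an amine or a carboxylic acid.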